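From 2,4-difluorophenyl to 4-chlorophenyl on the sulfonyl sulfur

A few compounds are considered here, and "the series" means these few. Any claim that something is new, unique, unknown or untested is made for them only; others in the source may bear on it.

In a functional assay on K562 cells (Homo sapiens) for inhibition, read by trypan blue exclusion, with a stated time of 72 h (a higher number here means a weaker inhibitor, a lower number a stronger inhibitor), compound 1 `Cn1c(=O)c(S(=O)(=O)c2ccc(F)cc2F)cc2cnc(Nc3cccc4[nH]ccc34)nc21` gives 1500 nM and sits close to compound 3 `Cn1c(=O)c(S(=O)(=O)c2ccc(F)cc2F)cc2cnc(Nc3cnc4[nH]ccc4c3)nc21` at 750 nM in the middle of the numbers shown. The gap between them is a 2.0-fold lower number from compound 1 to compound 3 (0.30 log units; within the scatter) and does not separate the two. Compound 2 `Cn1c(=O)c(S(=O)(=O)c2ccc(F)cc2F)cc2cnc(Nc3ccc4occc4c3)nc21` gives 15000 nM and stands apart, with a 10-fold higher number from compound 1 to compound 2 (1.00 log units; beyond the scatter) and a 20-fold lower number from compound 2 to compound 3 (1.30 log units; beyond the scatter) as its steps.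

Compound 4 `Cn1c(=O)c(S(=O)(=O)c2ccc(Cl)cc2)cc2cnc(Nc3cccc4[nH]ccc34)nc21` differs from compound 1 in one place, 4-chlorophenyl in place of 2,4-difluorophenyl on a sulfonyl sulfur in which 4-chlorophenyl stands in place of 2,4-difluorophenyl on a sulfonyl sulfur. Among the compounds with values here, all three measured steps alter the group on a nitrogen on an aromatic ring, so none of them bears directly on this change, and the data hold no measured step at the sulfonyl sulfur. In this assay no step beyond the scatter is therefore expected, and the expected step is a 1.3-fold higher number from compound 1 to compound 4 (0.12 log units; within the scatter) with wide uncertainty. Compound 4 is estimated at 2000 nM (expected range 500 nM to 8000 nM).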

Compound 4, half-maximal inhibitory concentration: 5000 nM
For compound 4 the middle estimate is 2.5-fold (0.40 log units) below the measured one, within the range that was stated.
By their numbers in this assay, from the lowest: compounds 3 and 1 (each within the scatter of the next); then compound 4; then compound 2.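

Within the data shown here, the step at the sulfonyl sulfur is the first one here that leaves the group on the nitrogen untouched: in this assay there is a 3.3-fold higher number from compound 1 to compound 4 (0.52 log units; beyond the scatter) on replacing 2,4-difluorophenyl with 4-chlorophenyl. The number therefore responds to the aromatic group on the sulfonyl sulfur as well as to the group on the nitrogen, and with 1H-indol-4-yl held fixed, 4-chlorophenyl gives the weaker inhibitor of the pair. No measurement offered here accounts for this difference.

A single step cannot separate the loss of the two fluorines from the arrival of the chlorine, and 4-fluorophenyl or 2-chloro-4-fluorophenyl on the same sulfur would bear on that. From the compounds shown here alone, it also remains open whether the step would hold with 1H-pyrrolo[2,3-b]pyridin-5-yl as in compound 3, the nitrogen substituent of that compound.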